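Trading One Aryl Group for Another in a Cytotoxicity Series

This account rests on a few compounds, and the source may have more. Where it says the series, first, only, none or still open, it means among the compounds named here.

Within the data shown here, two related compounds have numbers so far. In an ADME assay on L02 cells (Homo sapiens) for cytotoxicity, read by MTT assay, with a stated time of 24 h (on this read-out higher numbers stand for weaker inhibition and lower numbers for stronger inhibition), compound 1 (`COc1cc(/C=C2\CN(S(=O)(=O)c3ccc(F)cc3)C/C(=C\c3cc(OC)c(OC)c(OC)c3)C2=O)cc(OC)c1OC`) gives 12100 nM and compound 2 (`O=C1/C(=C/c2cccc([N+](=O)[O-])c2)CN(S(=O)(=O)c2ccc(F)cc2)C/C1=C\c1ccccc1F`) gives 17000 nM on the same read-out. Compound 2 thus sits within the usual scatter of compound 1, and the pair cannot be told apart. Compound 3 (`COc1cc(/C=C2\CN(S(=O)(=O)c3ccc(F)cc3)C/C(=C\c3cccc([N+](=O)[O-])c3)C2=O)cc(OC)c1OC`) differs from compound 2 in one place (3,4,5-trimethoxyphenyl in place of 2-fluorophenyl on a double-bonded chain carbon bound to a double-bonded ring carbon), with 3,4,5-trimethoxyphenyl in place of 2-fluorophenyl on a double-bonded chain carbon bound to a double-bonded ring carbon. Compound 1 also carries 3,4,5-trimethoxyphenyl and gives 12100 nM in this assay while staying within the scatter of compound 2, so no change beyond the scatter is expected. The expected move is a 1.2-fold lower number from compound 2 to compound 3 (0.08 log units; within the scatter) and remains small. For compound 3 the estimated value is 14000 nM with 7000 nM to 28000 nM as the range of that estimate.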

Compound 3, half-maximal inhibitory concentration: 18800 nM
The estimate for compound 3 lay 1.3-fold (0.13 log units) below the measured number; measured number inside the range.
By their numbers in this assay, from the lowest: compounds 1, 2 and 3 (each within the scatter of the next).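

In this assay, 3,4,5-trimethoxyphenyl in place of 2-fluorophenyl on a double-bonded chain carbon bound to a double-bonded ring carbon gives a 1.1-fold higher number from compound 2 to compound 3 (0.04 log units; within the scatter), so even this exchange of a 7-heavy-atom group for a 12-heavy-atom group carrying hydrogen-bond acceptors leaves the read-out unchanged within the scatter. At the same kind of position, 3-nitrophenyl in place of 3,4,5-trimethoxyphenyl gives a 1.6-fold higher number from compound 1 to compound 3 (0.19 log units; within the scatter), which is also within the scatter, so neither single exchange of one aryl group for another separates these compounds. No measurement available here explains this lack of separation.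

All the groups compared at this position are substituted phenyl rings. On these data alone, whether an amine, a carboxylic acid or a longer alkyl chain there would shift the number beyond the scatter remains open.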